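A few compounds are considered here, and "the series" means these few. Any claim that something is new, unique, unknown or untested is made for them only; others in the source may bear on it.

Compound 1 `C[C@H](/N=C(\NC#N)Nc1cc(C(F)(F)F)cc(C(F)(F)F)c1)C(C)(C)C` and compound 2 `C[C@@H](/N=C(\NC#N)Nc1cc(C(F)(F)F)cc(C(F)(F)F)c1)C(C)(C)C` share one skeleton and differ only in configuration as drawn at a stereocentre on the saturated chain carbon. In a functional assay (aorta) with Rattus norvegicus as the target (on this read-out lower numbers stand for stronger inhibition and higher numbers for weaker inhibition), compound 1 gives 11900 nM, and in this assay compound 2 gives 20300 nM. Going by the values given here, the step of a 1.7-fold higher number from compound 1 to compound 2 (0.23 log units; within the scatter) is the only measured comparison here, and it rests on (the fact that compounds 1 and 2 differ only in the configuration as drawn). On the numbers shown, compound 2 has the highest number of the two, with compound 1 as its nearest neighbour, the two lying within the scatter of each other.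

Compound 3 `CC(C)/N=C(\NC#N)Nc1cc(C(F)(F)F)cc(C(F)(F)F)c1` is built from compound 2 by the change (isopropyl in place of 1,2,2-trimethylpropyl on a double-bonded nitrogen). Among the compounds with values here, no measured step here alters the group on the double-bonded nitrogen, so the stereo step between compound 1 and compound 2, itself within the scatter, gives no guidance on the size or direction of this change. The expectation for compound 3 therefore stays close to compound 2, with a step of a 1.0-fold lower number from compound 2 to compound 3 (0.01 log units; within the scatter) expected in this assay and a broad range to cover the lack of evidence. Compound 3 is estimated at 20000 nM in this assay, between 6000 nM and 70000 nM.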

Compound 3, half-maximal inhibitory concentration: 61000 nM
Estimate against measurement, compound 3: 3.1-fold (0.48 log units) below, within the range that was stated.
By their numbers in this assay, from the lowest: compounds 1 and 2 (each within the scatter of the next); then compound 3.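

In this assay, going by these compounds alone, replacing 1,2,2-trimethylpropyl with isopropyl on the double-bonded nitrogen gives the first step in this set that lies beyond the scatter: a 3.0-fold higher number from compound 2 to compound 3 (0.48 log units; beyond the scatter). The same replacement read from the other configuration gives a 5.1-fold higher number from compound 1 to compound 3 (0.71 log units; beyond the scatter), so both drawn forms of the 1,2,2-trimethylpropyl compound carry lower numbers than the isopropyl compound, whereas the change of configuration alone amounts to a 1.7-fold higher number from compound 1 to compound 2 (0.23 log units; within the scatter). At this position, then, the read-out responds to which group is present, with the direction the same from either configuration, but nothing given here explains that response in terms of a property of either group.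

With only these two groups at this position, the compounds shown leave open whether the number would keep moving the same way with a longer chain, or how a cyclohexyl ring, an amine or a carboxylic acid placed there would compare. They also leave open what replacing the trifluoromethyl groups with chlorine or methoxy would do, as those groups are the same in all three compounds.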